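Dropping the Hydroxy: From Compound 2 to Compound 3

The compounds below may be only part of what the source reports. "The series", "measured", "known", "first", "only" and "open" are said of these compounds alone.

Measured so far in an ADME assay on microsomes from liver (Homo sapiens) for metabolic stability, read by LC-MS, using NADPH, with a stated time of 10 min, tested at 10 uM; a lower number here means that the compound disappears faster, a higher number that the compound lasts longer:
- Compound 1 `Nc1ncnc2c1c(Oc1cc(C(F)(F)F)ccn1)nn2C1CCCC1`: 0.333 h
- Compound 2 `Nc1ncnc2c1c(Oc1cc(C(F)(F)F)ccn1)nn2C1CCC(O)C1`: > 2.41 h

Compound 2 stands at the limit of > 2.41 h in this assay, at which 1 of the 2 values shown sits. For compound 2 there is only this limit of the assay and no number.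

The next structure is compound 3 `Nc1ncnc2c1c(Oc1cc(C(F)(F)F)ccn1)nn2C1CCCCC1`, with cyclohexyl in place of 3-hydroxycyclopentyl on an aromatic nitrogen.

For the measured compounds named here, one measured step bears on this change. Hydroxy in place of hydrogen on a saturated ring carbon gave an at least 7.2-fold higher number from compound 1 to compound 2 (0.85 log units; beyond the scatter). Compound 3 carries no hydroxy, so that step is read in reverse, and a drop of similar size is expected in this assay. Compound 1, which also lacks the hydroxy, gives 0.333 h, so compound 3 is expected to lie close to it. Going by the values given here, no measured compound carries the six-membered ring, which widens the range.

The expected step is an at least 8.0-fold lower number from compound 2 to compound 3 (0.90 log units; beyond the scatter).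

For compound 3 the estimated half-life is 0.3 h, with an expected range of 0.12 h to 0.7 h.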

Compound 3, half-life: 0.55 h
The estimate for compound 3 lay 1.8-fold (0.26 log units) below the measured number; the measured number falls inside the stated range.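

In this assay the result separates ring size from the hydroxy at this position: cyclohexyl in place of cyclopentyl on an aromatic nitrogen gives a 1.7-fold higher number from compound 1 to compound 3 (0.22 log units; within the scatter) and so leaves the two carbon-only rings indistinguishable here. Cyclohexyl in place of 3-hydroxycyclopentyl gives an at least 4.3-fold lower number from compound 2 to compound 3 (0.64 log units; beyond the scatter) and runs opposite to an at least 7.2-fold higher number from compound 1 to compound 2 (0.85 log units; beyond the scatter) in direction, so among these three compounds only the hydroxy-bearing compound 2 stands apart, and none goes against that reading. The full size of both steps stays open, as compound 2 has a limit and not a number: the limit of > 2.41 h in this assay, at which 1 of the 3 values shown sits.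

From the compounds shown here alone, it remains open whether a hydroxy on the cyclohexyl ring would give a step of similar size to the one seen on the cyclopentyl ring. Going by these compounds, it is also open whether the step is specific to the hydroxy or would also appear with another group on the saturated ring, such as an amine, a methoxy or a carboxylic acid.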